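Methyl for Fluoro on a Sulfonamide Oxadiazole

The source may report more compounds than this note shows. Statements on the series, on what has been measured and on what is new or still open speak of the compounds shown alone.

Three compounds have been measured in an assay on cells for inhibition of Amine oxidase [flavin-containing] A (Homo sapiens), read by fluorescence and spectrophotometry, using microsomes, with a stated time of 20 min; a lower number here means a stronger inhibitor, a higher number a weaker inhibitor:
compound 1 `NS(=O)(=O)c1ccc(C(=O)NNC(=O)c2ccccc2)cc1` gives 62800 nM;
compound 2 `N#Cc1ccc(-c2nnc(-c3ccc(S(N)(=O)=O)cc3)o2)cc1` gives 24300 nM;
compound 3 `NS(=O)(=O)c1cccc(-c2nnc(-c3ccc(F)cc3)o2)c1` gives 34400 nM.

Compound 3 sits within the scatter of both compound 2 and compound 1, so no order among the three numbers can be read. Compound 4 `Cc1ccc(-c2nnc(-c3cccc(S(N)(=O)=O)c3)o2)cc1` differs from compound 3 in one place: methyl in place of fluoro on an aromatic carbon. Within the data shown here, no pair of measured compounds shows a change of this kind, so the data give no guide to its effect. The step from compound 3 to compound 4 in this assay is expected to be small and to stay within the scatter, in no settled direction; the expected step is a 1.1-fold lower number from compound 3 to compound 4 (0.03 log units; within the scatter). Compound 4 is therefore estimated to give about 32000 nM, within a range of 12000 nM to 85000 nM.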

Compound 4, half-maximal inhibitory concentration: 61400 nM
The estimate for compound 4 lay 1.9-fold (0.28 log units) below the measured number, and the stated range covers the measured number.
By their numbers in this assay, from the lowest: compounds 2, 3, 4 and 1 (each within the scatter of the next, the first and the last beyond it).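

In this assay, among these compounds, the change from 4-fluorophenyl to 4-methylphenyl gives a 1.8-fold higher number from compound 3 to compound 4 (0.25 log units; within the scatter) and is the first single change that can be read in this set. At this position, the numbers do not separate methyl from fluoro. No measured evidence bears on this result.

The compounds shown leave open whether an amine or a carboxylic acid at this position would move the number beyond the scatter. They also leave open what chlorine or a longer chain would do there.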